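A few compounds are considered here, and "the series" means these few. Any claim that something is new, unique, unknown or untested is made for them only; others in the source may bear on it.

In a functional assay on L1210 cells (Mus musculus) for inhibition (on this read-out lower numbers stand for stronger inhibition and higher numbers for weaker inhibition), compound 1 (`O=C1/C(=C/c2cccc(Cl)c2)CCCc2ccccc21`) gives 52300 nM and compound 2 (`O=C1/C(=C/c2cccc(Br)c2)CCCc2ccccc21`) gives 51000 nM as its value, so compound 2 stands level with compound 1, within the scatter. Compound 3 (`Cc1cccc(/C=C2\CCCc3ccccc3C2=O)c1`) has methyl in place of bromo on an aromatic carbon. Among the measured compounds shown here, the one measured step that bears on this, bromo in place of chloro on an aromatic carbon, is small (a 1.0-fold lower number from compound 1 to compound 2 (0.01 log units; within the scatter)), and no measurement yet covers methyl. No step beyond the scatter is therefore expected in this assay for this change. The expected step is small (a 1.0-fold lower number from compound 2 to compound 3 (0.01 log units; within the scatter)). Compound 3 is estimated at 50000 nM with a range from 24000 nM to 100000 nM as the expected span.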

Compound 3, half-maximal inhibitory concentration: 54400 nM
Compound 3: the middle estimate sits 1.1-fold (0.04 log units) below what was measured; the range from low to high includes it.
By their numbers in this assay, from the lowest: compounds 2, 1 and 3 (each within the scatter of the next).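

Methyl, the first group at this place that is not a halogen, stands level with both halogens in this assay, with a 1.1-fold higher number from compound 2 to compound 3 (0.03 log units; within the scatter) and a 1.0-fold higher number from compound 1 to compound 3 (0.02 log units; within the scatter) as its steps. On this aromatic carbon, meta to a large group, chloro, bromo and methyl therefore cannot be told apart on this read-out. Nothing available offers an explanation for this result.

The compounds shown leave open whether an amine, a carboxylic acid or a methoxy group at this place would also stand level. They also leave open whether these three groups would stand level elsewhere on the ring.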